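Swapping Nitro for Amino in a Bromo Compound

The source may hold more compounds than are shown below. What is called first, only, known or untested is meant among the compounds shown, and "the series" means these compounds.

Measured in a functional assay on K562 cells (Homo sapiens) for cytotoxicity, read by trypan blue exclusion, with a stated time of 96 h; on this read-out higher numbers stand for weaker inhibition and lower numbers for stronger inhibition:
- compound 1 `COc1cc(OC)c(/C=C/S(=O)(=O)Cc2ccc(OC)c(N)c2)c(OC)c1`: 2.5 nM
- compound 2 `COc1cc(OC)c(/C=C/S(=O)(=O)Cc2cc(N)ccc2OC)c(OC)c1`: 7500 nM
- compound 3 `COc1cc(OC)c(/C=C/S(=O)(=O)Cc2ccc(Br)c([N+](=O)[O-])c2)c(OC)c1`: 25000 nM

In this assay compound 3 gives 25000 nM, the highest of the three numbers and clearly beyond the scatter from both others, so it inhibits least in this small set. Compound 4 `COc1cc(OC)c(/C=C/S(=O)(=O)Cc2ccc(Br)c(N)c2)c(OC)c1` comes from compound 3 by a single change, amino in place of nitro on an aromatic carbon, ortho to a bromo group (amino in place of nitro on an aromatic carbon).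

For the measured compounds named here, no measured pair makes this exact exchange, so the evidence is indirect. Going by the values given here, the only measured step, a 3000-fold higher number from compound 1 to compound 2 (3.48 log units; beyond the scatter), puts 5-amino-2-methoxyphenyl in place of 3-amino-4-methoxyphenyl. It is large and shows that a modest edit can move the number a long way in this set. Both measured amino compounds lie below compound 3, with compound 1 at 2.5 nM and compound 2 at 7500 nM. Among the compounds with values here, that is only two compounds, and their wide spread leaves the size of any gain uncertain.

A large move toward stronger inhibition is therefore expected, beyond the scatter. The expected step is a 170-fold lower number from compound 3 to compound 4 (2.22 log units; beyond the scatter). For compound 4 the estimated value is 150 nM, with an expected range from 5 nM to 4000 nM.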

Compound 4, half-maximal inhibitory concentration: 750 nM
Compound 4: the middle estimate sits 5.0-fold (0.70 log units) below what was measured, within the range that was stated.
By their numbers in this assay, from the lowest: compound 1; then compound 4; then compound 2; then compound 3.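

In this assay, amino in place of nitro on this aromatic carbon, ortho to a bromo group, gives a 33-fold lower number from compound 3 to compound 4 (1.52 log units; beyond the scatter) and so shows a large move toward stronger inhibition with the bromo group held fixed. The amino group alone does not settle the number, however: with it kept in place, bromo in place of methoxy gives a 300-fold higher number from compound 1 to compound 4 (2.48 log units; beyond the scatter) and marks the group ortho to the amino group as a second strong influence on the read-out. The arrangement of the ring matters as well, since 3-amino-4-bromophenyl in place of 5-amino-2-methoxyphenyl gives a 10-fold lower number from compound 2 to compound 4 (1.00 log units; beyond the scatter) and places compound 4 between the two amino compounds that carry methoxy.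

From the compounds shown here alone, this nitro-to-amino exchange is seen only beside bromo, so its size beside methoxy stays open, as does the outcome with a hydroxyl or acetamide group on the same carbon, or with chloro in place of bromo. Nothing measured here explains why the numbers move as they do.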